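From 3,5-dimethylbenzyl to benzyl on compound 1

The source may report more compounds than this note shows. Statements on the series, on what has been measured and on what is new or still open speak of the compounds shown alone.

Compound 1 (`CCc1c(Cc2cc(C)cc(C)c2)n(COCc2ccc(C(=O)/C=C(\O)C(=O)O)cc2)c(=O)[nH]c1=O`) sits at a limit in an ADME assay on PBMC cells (Homo sapiens) for cytotoxicity (on this read-out higher numbers stand for lower toxicity in this test and lower numbers for higher toxicity in this test), where compound 1 gives > 10000 nM, which is a limit and not a number. Compound 2 (`Cc1cc(C)cc(Cc2c(C(C)C)c(=O)[nH]c(=O)n2COCc2ccc(C(=O)/C=C(\O)C(=O)O)cc2)c1`) gives > 10000 nM, also a limit. The record so far is therefore (the limit of > 10000 nM in this assay, at which 2 of the 2 values shown sit). For the measured compounds named here, the only measured step is a step that the two limits leave unreadable from compound 1 to compound 2, so it offers no size to carry over.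

Compound 3 (`CCc1c(Cc2ccccc2)n(COCc2ccc(C(=O)/C=C(\O)C(=O)O)cc2)c(=O)[nH]c1=O`) differs from compound 1 as follows: phenyl in place of 3,5-dimethylphenyl on a saturated chain carbon bound to an aromatic carbon. In short, it has phenyl in place of 3,5-dimethylphenyl on a saturated chain carbon bound to an aromatic carbon. Going by the values given here, no measured step covers this change, so no step beyond the scatter is expected in this assay, and no direction can be argued. The expected step is a step that the limit leaves unreadable from compound 1 to compound 3. A report as a limit again is the likeliest outcome. For compound 3 the estimated value is 15000 nM, with an expected range from 6000 nM to 50000 nM.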

Compound 3, half-maximal cytotoxic concentration: > 10000 nM
Compound 3: a limit, no number (the forecaster's own chance of this, stated with the estimate: 80%); the middle value does not contradict the limit.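

No new step can be read between compound 1 and compound 3 in this assay, since both are reported only as limits: the limit of > 10000 nM in this assay, at which 3 of the 3 values shown sit.

The compounds shown leave open where their half-maximal cytotoxic concentrations actually lie, and whether phenyl and 3,5-dimethylphenyl differ at all on this read-out.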